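The compounds below may be only part of what the source reports. "The series", "measured", "known", "first", "only" and "open" are said of these compounds alone.

In an assay on cells for agonist activity at vitamin D3 receptor (Homo sapiens), with a stated time of 96 h (a lower number here means that less compound is needed, a higher number that more compound is needed for the effect), compound 2 `CCC(C)C(NC(=O)c1ccc(C(CC)(CC)c2ccc(OCCC(O)(CC)CC)c(C)c2)n1CC)C(=O)OC` gives > 10000 nM, which is a limit of the assay rather than a number. Compound 1 `CCn1c(C(=O)NCC#N)ccc1C(CC)(CC)c1ccc(OCCC(O)(CC)CC)c(C)c1` gives 1080 nM in this assay, and compound 3 `CCC(C)C(NC(=O)c1ccc(C(CC)(CC)c2ccc(OCCC(O)(CC)CC)c(C)c2)n1CC)C(=O)O` gives 860 nM. The step from compound 1 to compound 2 gave an at least 9.2-fold higher number from compound 1 to compound 2 (0.96 log units; beyond the scatter), and the step from compound 2 to compound 3 gave an at least 11-fold lower number from compound 2 to compound 3 (1.06 log units; beyond the scatter); both of these rest on the limit (the limit of > 10000 nM in this assay, at which 1 of the 3 values shown sits). Between compound 1 and compound 3 the step was a 1.3-fold lower number from compound 1 to compound 3 (0.10 log units; within the scatter). Compound 4 `CCn1c(C(=O)NC(C)CO)ccc1C(CC)(CC)c1ccc(OCCC(O)(CC)CC)c(C)c1` differs from compound 2 by a group of 4 heavy atoms (3 carbon, 1 oxygen; no ring) in place of a group of 9 heavy atoms (7 carbon, 2 oxygen; no ring), on an amide-type nitrogen. The two measured steps that start or end at compound 2 both show that the group of 9 heavy atoms goes with the limit, while the smaller groups on the amide-type nitrogen in compound 1 and compound 3 go with measurable numbers of similar size. A measurable number is therefore expected for compound 4, and the step is estimated as an at least 6.6-fold lower number from compound 2 to compound 4 (0.82 log units; beyond the scatter). The estimate for compound 4 is 1500 nM, with a range from 500 nM to 5000 nM.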

Compound 4, half-maximal effective concentration: 96 nM
Estimate against measurement, compound 4: 16-fold (1.19 log units) above; the whole stated range lies above it.
By their numbers in this assay, from the lowest: compound 4; then compounds 3 and 1 (each within the scatter of the next). At a limit, above all of these: compound 2.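

On the amide-type nitrogen, 1-(hydroxymethyl)ethyl produces steps beyond the scatter from both compounds with measurable numbers. In this assay, going by these compounds alone, replacing cyanomethyl gives an 11-fold lower number from compound 1 to compound 4 (1.05 log units; beyond the scatter) and replacing 1-carboxy-2-methylbutyl gives a 9.0-fold lower number from compound 3 to compound 4 (0.95 log units; beyond the scatter), so this position can lower the number and not only send it to a limit, which the earlier compounds did not show. The remaining step, an at least 100-fold lower number from compound 2 to compound 4 (2.01 log units; beyond the scatter), gives only a bound, since its starting value is a limit of the assay: the limit of > 10000 nM in this assay, at which 1 of the 4 values shown sits.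

The compounds shown leave open whether the gain goes with the hydroxyl group, the branching methyl or both. A 2-hydroxyethyl group, a propyl chain or an amine in place of the hydroxyl group would be needed to separate these.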